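Adding a Methyl to Compound 2 in Paw Edema

This account rests on a few compounds, and the source may have more. Where it says the series, first, only, none or still open, it means among the compounds named here.

Two measured compounds share a core. Compound 1 `Cc1cccn2c(C(=O)c3sc(N)nc3N(C)C)cnc12` and compound 2 `Nc1nc(-c2ccccc2)c(C(=O)c2cnc3ccccn23)s1` were both tested in a functional assay on the whole organism (strain Sprague-Dawley) for inhibition, with Rattus norvegicus as the target, read by paw edema, with stated times of 1 h and 3 h, at a dose of 50 mg/kg by the oral route; on this read-out lower numbers stand for less inhibition and higher numbers for more inhibition at the one dose given (going by the name of the read-out). In this assay compound 1 gives 81%, and compound 2 gives 40%, the lower of the two numbers, with a gap between them that lies beyond the usual scatter. Compound 1 and compound 2 differ in more than one place, so that gap cannot be tied to any single change.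

Compound 3 `Cc1cccn2c(C(=O)c3sc(N)nc3-c3ccccc3)cnc12` has not yet been measured. It differs from compound 2 by methyl in place of hydrogen on an aromatic carbon. Compound 1 carries that same methyl, but its other differences from compound 2 mean its higher value is at best a hint about what the methyl alone does. The step from compound 2 to compound 3 is therefore expected to be small to moderate and upward, and it may not rise beyond the scatter. For compound 3 the expected value in this assay is 52%, within a range from 32% to 72%, which amounts to an expected step of a number 12 percentage points higher from compound 2 to compound 3 (beyond the scatter).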

Compound 3, a percentage reported as inhibition, in the whole organism at one dose (the size of the read-out at that dose, not a potency): 20%
Beside the measured number, compound 3's estimate is 32 percentage points above it; the whole stated range lies above it.
By their numbers in this assay, from the lowest: compound 3; then compound 2; then compound 1.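

In this assay, within the data shown here, methyl in place of hydrogen on an aromatic carbon, two atoms from the ring nitrogen, gives a number 20 percentage points lower from compound 2 to compound 3 (beyond the scatter) as the only change, so on this core the methyl goes with less inhibition and not more. Phenyl in place of dimethylamino on an aromatic carbon, with the methyl present on both sides, gives a number 61 percentage points lower from compound 1 to compound 3 (beyond the scatter) and shows that the hint drawn from compound 1 belonged to the dimethylamino group and not to the methyl. No measurement shown here explains why either step goes the way it does.

On these data alone, whether the drop at this position is particular to methyl stays open, since a single group cannot show how the position responds to others, such as fluorine, methoxy or a longer chain like ethyl. As far as these compounds go, it is also open how much of the high value of compound 1 would survive without its methyl, or with a smaller amine such as methylamino in place of dimethylamino.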